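The source may report more compounds than this note shows. Statements on the series, on what has been measured and on what is new or still open speak of the compounds shown alone.

Compound 1 `COc1ccccc1-c1cnc(C(=O)CCCCCCc2ccccc2)o1` is examined in an assay (Rattus norvegicus) for inhibition of Fatty-acid amide hydrolase 1 (Homo sapiens) (a higher number here means a weaker inhibitor, a lower number a stronger inhibitor), where compound 1 gives 400 nM. Among the three measured compounds it holds the second highest number: compound 2 `NS(=O)(=O)c1ccccc1-c1cnc(C(=O)CCCCCCc2ccccc2)o1` gives 1500 nM in this assay, and compound 3 `COC(=O)c1cccc(-c2cnc(C(=O)CCCCCCc3ccccc3)o2)c1` gives 12 nM, so compound 1 sits nearer to compound 2 and furthest from compound 3, with both gaps beyond the scatter.

Compound 4 `N#Cc1cccc(-c2cnc(C(=O)CCCCCCc3ccccc3)o2)c1` differs from compound 1 in one place: 3-cyanophenyl in place of 2-methoxyphenyl on an aromatic carbon. Among the compounds with values here, no measured step covers this exact change. Within the data shown here, the only measured single-point step, a 3.8-fold higher number from compound 1 to compound 2 (0.57 log units; beyond the scatter), replaces the substituent on the phenyl without moving it, and it lies in the opposite sense to what the values of compound 3 and compound 1 show, where a 3-substituted phenyl pairs with a markedly lower number than the 2-methoxyphenyl. On that basis the change to 3-cyanophenyl is expected to bring a lower number in this assay, though how far the nitrile follows the ester of compound 3 cannot be read from two compounds alone.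

For compound 4 the estimate in this assay is 60 nM, within a range from 15 nM to 250 nM, which means an expected step of a 6.7-fold lower number from compound 1 to compound 4 (0.82 log units; beyond the scatter).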

Compound 4, inhibition constant: 15 nM
Beside the measured number, compound 4's estimate is 4.0-fold (0.60 log units) above it, and the stated range covers the measured number.
By their numbers in this assay, from the lowest: compounds 3 and 4 (each within the scatter of the next); then compound 1; then compound 2.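

Putting 3-cyanophenyl in place of 2-methoxyphenyl, on the aromatic carbon next to the ring oxygen, brings a 27-fold lower number from compound 1 to compound 4 (1.43 log units; beyond the scatter) in this assay, a large step that shows how strongly the number at this position depends on the aryl group carried there. Nitrile in place of methoxycarbonyl gives a 1.3-fold higher number from compound 3 to compound 4 (0.10 log units; within the scatter), so the low number seen with compound 3 is not confined to that ester and also appears with a nitrile, and the two compounds cannot be told apart in this assay. Nothing available here accounts for the size of the step from the methoxy compound to the nitrile, or for the close match between the nitrile and the ester.

Because compound 4 differs from compound 1 both in the group and in where that group stands on the phenyl, the compounds shown do not separate the effect of the group from that of its placement. They also leave open whether a carboxylic acid or an amine on the phenyl would keep a number like that of compound 4 (15 nM) or fall back towards that of compound 1 (400 nM).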